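Swapping pyridin-4-yl back to a thiophene

The source may report more compounds than this note shows. Statements on the series, on what has been measured and on what is new or still open speak of the compounds shown alone.

Compound 1 `COc1cc(NCc2ccc(C)s2)ccc1-c1cnco1`: 34400 nM
Compound 2 `COc1cc(NCc2ccncc2)ccc1-c1cnco1`: 72200 nM

In an ADME assay on Huh-7 cells (Homo sapiens) for cytotoxicity, read by MTT assay, with a stated time of 96 h (on this read-out higher numbers stand for lower toxicity in this test and lower numbers for higher toxicity in this test), compound 2 gives 72200 nM, the higher of the two numbers. Compound 3 `CCc1ccc(CNc2ccc(-c3cnco3)c(OC)c2)s1` has 5-ethylthiophen-2-yl in place of pyridin-4-yl on a saturated chain carbon bound to a nitrogen on an aromatic ring. Going by the values given here, only one measured step bears on this change: a 2.1-fold higher number from compound 1 to compound 2 (0.32 log units; beyond the scatter). Compound 1, which carries 5-methylthiophen-2-yl, gives 34400 nM, so a similarly modest step to a lower number is expected in this assay. The expected change is a 2.3-fold lower number from compound 2 to compound 3 (0.37 log units; beyond the scatter). For compound 3 the estimated value is 31000 nM, with a range from 14000 nM to 65000 nM.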

Compound 3, half-maximal cytotoxic concentration: 39100 nM
Estimate against measurement, compound 3: 1.3-fold (0.10 log units) below; low and high end bracket the measured number.
By their numbers in this assay, from the lowest: compounds 1, 3 and 2 (each within the scatter of the next, the first and the last beyond it).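

In this assay the change to 5-ethylthiophen-2-yl gives a 1.8-fold lower number from compound 2 to compound 3 (0.27 log units; within the scatter) and so does not clearly separate these two compounds, although compound 1, with its 5-methylthiophen-2-yl, stood beyond the scatter from compound 2. Methyl in place of hydrogen on a saturated chain carbon bound to an aromatic carbon gives a 1.1-fold higher number from compound 1 to compound 3 (0.06 log units; within the scatter) so the two alkyl thiophenes cannot be told apart here. Nothing measured explains these numbers.

Going by these compounds, whether a longer chain than ethyl on the thiophene would shift the number remains open. So does the effect of an amine or a carboxylic acid there.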